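From 4-bromophenyl to 4-methylphenyl in the series

The source may hold more compounds than are shown below. What is called first, only, known or untested is meant among the compounds shown, and "the series" means these compounds.

In a functional assay on B16-F10 cells (Mus musculus) for antiproliferative activity, read by MTT assay, with a stated time of 48 h (a higher number here means a weaker inhibitor, a lower number a stronger inhibitor), compound 1 (`CC(=O)N1N=C(c2ccc(Br)cc2)CC1c1ccc2c(c1)OCCO2`) gives 44100 nM and compound 2 (`CC(=O)N1N=C(c2ccc(Br)cc2)CC1c1ccc2c(c1)OCCCO2`) gives 97000 nM as half-maximal inhibitory concentration. Compound 2 thus stands at the higher of the two numbers, which makes it the weaker inhibitor of the pair, and its gap to compound 1 lies beyond the usual scatter.

Compound 3 (`CC(=O)N1N=C(c2ccc(C)cc2)CC1c1ccc2c(c1)OCCCO2`) has no number yet. It keeps the core of compound 2 and differs in one place, on the 4-bromophenyl group, which becomes 4-methylphenyl: methyl in place of bromo on an aromatic carbon. Among the measured compounds shown here, no measured pair shows a change at this place, so the data set no direction and no shift beyond the scatter is expected. The anchor for the expectation is compound 2 at 97000 nM in this assay as the nearest measured neighbour. The expected step runs a 1.1-fold lower number from compound 2 to compound 3 (0.03 log units; within the scatter) and is estimated to stay within the scatter. For compound 3 the estimated value is 90000 nM with an expected range from 35000 nM to 230000 nM as the likely span.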

Compound 3, half-maximal inhibitory concentration: 89700 nM
The estimate for compound 3 lay 1.0-fold (0.00 log units) above the measured number; low and high end bracket the measured number.
By their numbers in this assay, from the lowest: compound 1; then compounds 3 and 2 (each within the scatter of the next).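

In this assay, the change from 4-bromophenyl to 4-methylphenyl on the core of compound 2 runs a 1.1-fold lower number from compound 2 to compound 3 (0.03 log units; within the scatter), the only reading at this place among the compounds shown. On this aromatic carbon, para to a large group, the read-out does not separate bromo from methyl, two groups that each count a single heavy atom and carry no hydrogen-bond donors or acceptors, which compound 1 and compound 2 could not show since both keep the 4-bromophenyl group. No measurement at hand bears on why the two groups read alike here.

As far as these compounds go, whether the same exchange reads alike on the core of compound 1, and whether an amine, a carboxylic acid or a longer alkyl chain at this place would move the number beyond the scatter, remains open. With a single step at this position, no trend across groups can be drawn from the compounds shown.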